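A few compounds are considered here, and "the series" means these few. Any claim that something is new, unique, unknown or untested is made for them only; others in the source may bear on it.

Measured in a physicochemical assay for solubility, read by nephelometry, measured as kinetic solubility, at pH 2.0; on this read-out higher numbers stand for higher solubility and lower numbers for lower solubility:

- compound 1 `CC(C)(C)c1cc(C(=O)Nc2cccc(CN)c2)n(Cc2ccccc2)n1`: > 100 ug/mL (a limit, not a number)
- compound 2 `CC(C)(C)c1cc(C(=O)Nc2ccccn2)n(Cc2ccccc2)n1`: 25 ug/mL
- compound 3 `NCc1csc(NC(=O)c2ccn[nH]2)n1`: > 100 ug/mL (a limit, not a number)

Among the measured compounds shown here, compound 2 holds the only actual number in the set. Everything else stands at the limit of > 100 ug/mL in this assay, at which 2 of the 3 values shown sit.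

The next step leads to compound 4 `CC(C)(C)c1cc(C(=O)Nc2ccncc2)n(Cc2ccccc2)n1`, with this change: pyridin-4-yl in place of pyridin-2-yl on an amide-type nitrogen. In short, pyridin-4-yl stands in place of pyridin-2-yl on an amide-type nitrogen, and the two compounds have the same atoms, joined differently.

For the measured compounds named here, one measured step bears on this, on the same kind of nitrogen: an at least 4.0-fold lower number from compound 1 to compound 2 (0.60 log units; beyond the scatter). Going by the values given here, that step exchanges a different group, so it shows only that a change at this place can move the read-out beyond the scatter. Among the compounds with values here, compound 3 offers no step for comparison.

A smaller move is expected here, and the direction is uncertain, with a slight rise favoured in this assay. The expected change is a 1.6-fold higher number from compound 2 to compound 4 (0.20 log units; within the scatter). For compound 4 the estimated value is 40 ug/mL, with an expected range of 15 ug/mL to 100 ug/mL.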

Compound 4, solubility: > 100 ug/mL
Compound 4 gave a limit, no number (the forecaster's own chance of this, stated with the estimate: 20%); at least 2.5-fold (0.39 log units) between middle value and limit.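

In this assay, pyridin-4-yl in place of pyridin-2-yl on the amide-type nitrogen gives an at least 4.0-fold higher number from compound 2 to compound 4 (0.60 log units; beyond the scatter) and so shows that the read-out at this place responds to how the same atoms are joined, not only to the exchange of a different group as in the earlier step. From the compounds shown here alone, the read-out of compound 4 is a limit, so the full size of this step stays unknown, and compound 4 joins the other compounds at that limit: the limit of > 100 ug/mL in this assay, at which 3 of the 4 values shown sit. With both values being limits, the step between compound 1 and compound 4 cannot be read.

Open, going by these compounds, is whether pyridin-3-yl on the same nitrogen would read like compound 2 or stand at the limit like compound 4. Also open, on these data alone, is how a carboxylic acid on a group at this place would read.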